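Moving the trifluoromethyl group on compound 3

The source may hold more compounds than are shown below. What is called first, only, known or untested is meant among the compounds shown, and "the series" means these compounds.

Measured in an ADME assay on HepG2 2.2.15 cells (Homo sapiens) for cytotoxicity; a lower number here means that less compound is tolerated, a higher number that more compound is tolerated:
- compound 1 `O=C(COc1ccccc1)OCCc1c(-c2ccccc2Cl)c2cc(Cl)ccc2[nH]c1=O` gives 81000 nM
- compound 2 `O=C(CCOc1ccccc1)OCCc1c(-c2ccccc2Cl)c2cc(Cl)ccc2[nH]c1=O` gives 46000 nM
- compound 3 `O=C(/C=C/c1cccc(C(F)(F)F)c1)OCCc1c(-c2ccccc2Cl)c2cc(Cl)ccc2[nH]c1=O` gives only a limit, > 1400000 nM

Compound 3 stands clear of the other two, with large measured steps: an at least 17-fold higher number from compound 1 to compound 3 (1.23 log units; beyond the scatter) and an at least 30-fold higher number from compound 2 to compound 3 (1.48 log units; beyond the scatter). As far as these compounds go, its true value remains open.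

Compound 4 `O=C(/C=C/c1ccc(C(F)(F)F)cc1)OCCc1c(-c2ccccc2Cl)c2cc(Cl)ccc2[nH]c1=O` makes one change: 4-(trifluoromethyl)phenyl in place of 3-(trifluoromethyl)phenyl on a double-bonded chain carbon bound to a double-bonded chain carbon. Within the data shown here, no measured step tests this swap. The two large steps replaced the whole group on the carbonyl carbon, and a 1.8-fold lower number from compound 1 to compound 2 (0.25 log units; within the scatter) altered only the chain. No step beyond the scatter is therefore expected in this assay, in either direction. The expected step is an at least 1.4-fold lower number from compound 3 to compound 4 (0.14 log units; that floor lies within the scatter). For compound 4 the estimated value is 1000000 nM, with an expected range from 100000 nM to 3000000 nM.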

Compound 4, half-maximal cytotoxic concentration: > 1400000 nM
Compound 4 gave a limit, no number; the forecaster's own chance of this, stated with the estimate: 50%; at least 1.4-fold (0.14 log units) between middle value and limit.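

Compound 4 also stands clear of the phenoxy compounds in this assay, with an at least 30-fold higher number from compound 2 to compound 4 (1.48 log units; beyond the scatter) and an at least 17-fold higher number from compound 1 to compound 4 (1.23 log units; beyond the scatter). The high tolerance seen for compound 3 therefore does not depend on the 3-(trifluoromethyl)phenyl group alone, as the 4-(trifluoromethyl)phenyl group shares it. The step from compound 3 to compound 4 cannot be read, because both results are limits and not numbers: the limit of > 1400000 nM in this assay, at which 2 of the 4 values shown sit.

Which placement of the trifluoromethyl group is better tolerated stays open. Also open, as far as these compounds go, is whether a nitrile or a methoxy group in place of trifluoromethyl would be tolerated as well.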